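The source may hold more compounds than are shown below. What is called first, only, known or untested is meant among the compounds shown, and "the series" means these compounds.

Within the data shown here, in a functional assay on RT-112 cells (Homo sapiens) for antiproliferative activity, read by MTT assay, with a stated time of 72 h (a higher number here means a weaker inhibitor of growth, a lower number a stronger inhibitor of growth), compound 3 `COc1cc(Nc2ncnc3c(NC(=O)Nc4ccc5c(c4)OCCO5)cccc23)cc(OC)c1` gives 2750 nM, the highest of the three numbers measured so far. Compound 1 `COc1cc(Nc2ncnc3c(NC(=O)Nc4ccc(C)cc4C)cccc23)cc(OC)c1` gives 1290 nM, and compound 2 `COc1cc(Nc2ncnc3c(NC(=O)Nc4cc(Cl)cc(Cl)c4)cccc23)cc(OC)c1` gives 30.2 nM. Compound 4 `COc1cc(Nc2ncnc3c(NC(=O)Nc4cccc(C)c4C)cccc23)cc(OC)c1` has not yet been measured. It carries 2,3-dimethylphenyl in place of 2,3-dihydro-1,4-benzodioxin-6-yl on an amide-type nitrogen. The closest guide is the modest step of a 2.1-fold higher number from compound 1 to compound 3 (0.33 log units; beyond the scatter), in which 2,3-dihydro-1,4-benzodioxin-6-yl replaces 2,4-dimethylphenyl. The change to compound 4 runs the other way and brings in a different dimethylphenyl, so a modest move to a lower number is expected. The large steps of a 43-fold lower number from compound 1 to compound 2 (1.63 log units; beyond the scatter) and a 91-fold higher number from compound 2 to compound 3 (1.96 log units; beyond the scatter) both involve 3,5-dichlorophenyl, which is absent here, but they show that this substituent can matter greatly, and so the expected range is kept wide. The estimated change is a 2.8-fold lower number from compound 3 to compound 4 (0.44 log units; beyond the scatter). Compound 4 is estimated at 1000 nM, with an expected range of 300 nM to 3000 nM.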

Compound 4, concentration for 50% growth inhibition: 5910 nM
For compound 4 the middle estimate is 5.9-fold (0.77 log units) below the measured one, outside the stated range (above it).
By their numbers in this assay, from the lowest: compound 2; then compound 1; then compound 3; then compound 4.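

In this assay the two dimethylphenyl groups on the amide-type nitrogen do not read alike: 2,3-dimethylphenyl in place of 2,4-dimethylphenyl gives a modest rise (a 4.6-fold higher number from compound 1 to compound 4 (0.66 log units; beyond the scatter)), so moving one methyl group alone shifts the number. Compared with 2,3-dihydro-1,4-benzodioxin-6-yl, 2,3-dimethylphenyl also gives a modest rise (a 2.1-fold higher number from compound 3 to compound 4 (0.33 log units; beyond the scatter)), while the gap to 3,5-dichlorophenyl is the largest step seen so far (a 200-fold higher number from compound 2 to compound 4 (2.29 log units; beyond the scatter)). Nothing measured here gives a reason for these steps.

The compounds shown leave open whether 3,5-dimethylphenyl would keep the low number of compound 2 or join the other methyl-bearing compounds, which would separate the effect of the chlorine atoms from that of their placement. Also open, going by these compounds, is how a phenyl ring carrying a single chlorine or an amine would read at this nitrogen.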